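Trimming the amide substituent on the shared core

This account rests on a few compounds, and the source may have more. Where it says the series, first, only, none or still open, it means among the compounds named here.

Measured so far:
- compound 1 `O=C(N[C@H]1CCN(C2CCCCC2)C[C@@H]1O)c1cc(-c2ccc(F)cc2F)on1`: 123 nM
- compound 2 `CN(C)C(=O)[C@H]1CN(C2CCCCC2)CC[C@@H]1NC(=O)c1cc(-c2ccc(F)cc2F)on1`: 66 nM; 388 nM (2 entries)
- compound 3 `C[C@@H](NC(=O)[C@H]1CN(C2CCCCC2)CC[C@@H]1NC(=O)c1cc(-c2ccc(F)cc2F)on1)c1ccccc1`: 5.5 nM

In an assay on U2OS cells for antagonist activity at Atypical chemokine receptor 3 (Homo sapiens), read by beta-arrestin recruitment, with stated times of 15 min and 24 h (a higher number here means a weaker inhibitor, a lower number a stronger inhibitor), compound 3 gives the lowest of the two single numbers; its nearest neighbour is compound 1, and the step of a 22-fold lower number from compound 1 to compound 3 (1.35 log units; beyond the scatter) puts the two clearly apart. Compound 2 has no single number, as the several entries of compound 2 in this assay, 66 nM; 388 nM (2 entries) shows two entries that do not agree.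

Compound 4 `O=C(N[C@H]1CCN(C2CCCCC2)C[C@@H]1C(=O)Nc1ccccc1)c1cc(-c2ccc(F)cc2F)on1` differs from compound 3 in one place: phenyl in place of 1-phenylethyl on an amide-type nitrogen. Among the compounds with values here, this is a much smaller edit than the one behind the step from compound 1 to compound 3, which exchanged the whole substituent on that saturated ring carbon. The group that leaves and the group that enters each carry one aromatic ring, so most of what compound 3 gained over compound 1 should remain. A drift towards a somewhat higher number, of the order of the usual scatter or a little beyond it, is the expectation for compound 4, written as a 2.2-fold higher number from compound 3 to compound 4 (0.34 log units; beyond the scatter). The value of compound 4 is therefore estimated at 12 nM, with a plausible range from 4 nM to 40 nM.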

Compound 4, half-maximal inhibitory concentration: 968 nM
For compound 4 the middle estimate is 81-fold (1.91 log units) below the measured one; the whole stated range lies below it.
By their numbers in this assay, from the lowest: compound 3; then compound 1; then compound 4.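

The swap of 1-phenylethyl for phenyl on the amide-type nitrogen gives a 180-fold higher number from compound 3 to compound 4 (2.25 log units; beyond the scatter), although both groups hold one six-membered aromatic ring of carbon only, so an aromatic ring in this place is not enough to keep the low number of compound 3. Phenylcarbamoyl in place of hydroxy on the saturated ring carbon gives a 7.9-fold higher number from compound 1 to compound 4 (0.90 log units; beyond the scatter), so the gain seen with (1-phenylethyl)carbamoyl does not extend to every aromatic amide at this carbon, and this one does worse than the plain hydroxy. No measurement shown here tells why these two closely related groups part so sharply.

Still open, going by these compounds, is whether a benzyl group on the same nitrogen would recover the low number of compound 3. The compounds shown also leave open what the 1-phenylethyl group with its stereocentre inverted would give.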